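A few compounds are considered here, and "the series" means these few. Any claim that something is new, unique, unknown or untested is made for them only; others in the source may bear on it.

Measured so far in an assay on isolated protein for activation of cGMP-dependent protein kinase 1 (Homo sapiens), read by ADP-Glo, with stated times of 120 min and 40 min; on this read-out lower numbers stand for an effect already at smaller amounts and higher numbers for an effect only at larger amounts of compound:
compound 1 `O=C(O)c1cncc(CN2CCC[C@H](O[C@H](CO)c3cc(Cl)cc(Cl)c3)[C@@H]2c2ccccc2)c1` gives 34000 nM;
compound 2 `OC[C@@H](O[C@H]1CCCN(Cc2ncc[nH]2)[C@H]1c1ccccc1)c1cc(Cl)cc(Cl)c1` gives 7000 nM;
compound 3 `OC[C@@H](O[C@H]1CCCN(Cc2cccc3nonc23)[C@H]1c1ccccc1)c1cc(Cl)cc(Cl)c1` gives 8000 nM.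

Compound 3 holds the second highest of these three numbers. Its distance from compound 2 is small, a 1.1-fold higher number from compound 2 to compound 3 (0.06 log units; within the scatter), so the two cannot be told apart here. Its distance from compound 1 is clear, a 4.3-fold lower number from compound 1 to compound 3 (0.63 log units; beyond the scatter).

Compound 4 `O=C(O)c1ccc2c(CN3CCC[C@H](O[C@H](CO)c4cc(Cl)cc(Cl)c4)[C@@H]3c3ccccc3)c[nH]c2c1` differs from compound 3 in one place: a group of 12 heavy atoms (9 carbon, 1 nitrogen, 2 oxygen; one five-membered aromatic ring with 1 hetero atom, one six-membered aromatic ring of carbon only) in place of a group of 9 heavy atoms (6 carbon, 2 nitrogen, 1 oxygen; one five-membered aromatic ring with 3 hetero atoms, one six-membered aromatic ring of carbon only), on a saturated chain carbon bound to an amine nitrogen in a ring. Among the measured compounds shown here, two measured steps bear on this change, since both replace the 5-carboxypyridin-3-yl group of compound 1 with a group that carries no carboxy group: a 4.9-fold lower number from compound 1 to compound 2 (0.69 log units; beyond the scatter) and a 4.3-fold lower number from compound 1 to compound 3 (0.63 log units; beyond the scatter). In both cases the compound with the carboxy group gave the higher number. For the measured compounds named here, the group entering in compound 4 again carries a carboxy group, now on a 6-carboxy-1H-indol-3-yl ring system with hydrogen-bond donors, which no measured compound shows. A modest step toward a higher number in this assay is therefore expected, with wide uncertainty. The estimate for compound 4 is 15000 nM, in the range 4000 nM to 60000 nM, which means an expected step of a 1.9-fold higher number from compound 3 to compound 4 (0.27 log units; within the scatter).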

Compound 4, half-maximal effective concentration in the cGMP-dependent protein kinase 1 assay: 22000 nM
Beside the measured number, compound 4's estimate is 1.5-fold (0.17 log units) below it; the range from low to high includes it.
By their numbers in the cGMP-dependent protein kinase 1 assay, from the lowest: compounds 2 and 3 (each within the scatter of the next); then compounds 4 and 1 (each within the scatter of the next).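

In the cGMP-dependent protein kinase 1 assay compound 4 gives 22000 nM and compound 1 gives 34000 nM, a pair within the scatter (a 1.5-fold lower number from compound 1 to compound 4 (0.19 log units; within the scatter)), so 6-carboxy-1H-indol-3-yl and 5-carboxypyridin-3-yl cannot be told apart on a saturated chain carbon bound to an amine nitrogen in a ring. In the cGMP-dependent protein kinase 1 assay, both groups without a carboxy group give clearly lower numbers than 6-carboxy-1H-indol-3-yl (a 2.8-fold higher number from compound 3 to compound 4 (0.44 log units; beyond the scatter) and a 3.1-fold higher number from compound 2 to compound 4 (0.50 log units; beyond the scatter)), and among these four compounds none goes against the split between those with and without a carboxy group. In a physicochemical assay for solubility, read by HPLC, with a stated time of 24 h, at pH 7 (a higher number here means a more soluble compound, a lower number a less soluble compound), compound 3 gives 154000 nM and compound 4 gives 128000 nM. The same change leaves no readable difference in the physicochemical assay (a 1.2-fold lower number from compound 3 to compound 4 (0.08 log units; within the scatter)), so the step seen in the cGMP-dependent protein kinase 1 assay comes with no separation in solubility between these two compounds.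

The compounds shown leave open whether the carboxylic acid itself or the ring carrying it goes with the higher numbers, a question that a plain 1H-indol-3-yl group, or a methyl ester or primary amide in place of the acid, could address. No measurement at hand gives a reason for any of these steps.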